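The source may hold more compounds than are shown below. What is called first, only, known or untested is meant among the compounds shown, and "the series" means these compounds.

Working notes on the series. Among the compounds with values here, compound 1 `CCCCCCCC/C=C\CCCCCCCC(=O)OCC1CCCCO1` is one of two compounds measured in an assay on membranes from cerebellum for inhibition of Fatty-acid amide hydrolase 1 (Rattus norvegicus); a lower number here means a stronger inhibitor, a higher number a weaker inhibitor: compound 1 gives 29000 nM, and compound 2 `O=C(OCC1CO1)c1ccc(-c2ccccc2)cc1` gives 35000 nM, the two numbers lying within the usual scatter of each other, so neither stands apart. Compound 3 `CCCCCC/C=C\CCCCCCCC(=O)OCC1CCCCO1` is not yet measured; it differs from compound 1 by hydrogen in place of ethyl on a saturated chain carbon, six bonds along the chain from a double-bonded chain carbon, a shortening of the chain at its far end. With no measured step of this kind in the series, the step from compound 1 to compound 3 is expected to be small, a 1.0-fold higher number from compound 1 to compound 3 (0.01 log units; within the scatter), within the scatter in either direction. Compound 3 is therefore estimated at 30000 nM, with a range from 10000 nM to 90000 nM.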

Compound 3, half-maximal inhibitory concentration: 10000 nM
The estimate for compound 3 lay 3.0-fold (0.48 log units) above the measured number; the range from low to high includes it.
By their numbers in this assay, from the lowest: compound 3; then compounds 1 and 2 (each within the scatter of the next).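

Shortening the chain at its far end, hydrogen in place of ethyl on a saturated chain carbon, six bonds along the chain from a double-bonded chain carbon, gives in this assay the first measured step of the series, a 2.9-fold lower number from compound 1 to compound 3 (0.46 log units; beyond the scatter) and so a modest but real change. The far end of the chain therefore bears on the number, which the two earlier compounds could not show. No supporting data bear on why this step occurs. Still open, from the compounds shown here alone, is whether further shortening continues the trend, and whether a longer chain reverses it. A carboxylic acid or a hydroxyl at the chain end also remains untested in the compounds shown.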